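The source may report more compounds than this note shows. Statements on the series, on what has been measured and on what is new or still open speak of the compounds shown alone.

Working notes on the catechol vinyl sulfone series. Of the compounds shown here, two have a number so far: compound 1 `CCCCCCCCCCCCS(=O)(=O)/C=C/c1ccc(O)c(O)c1` and compound 2 `O=S(=O)(/C=C/c1ccc(O)c(O)c1)CC1CCCC1`. In a functional assay, read by fluorescence and spectrophotometry, with a stated time of 1 h (on this read-out lower numbers stand for an effect already at smaller amounts and higher numbers for an effect only at larger amounts of compound), compound 2 gives 9400 nM, and compound 1 gives 8500 nM in this assay. Within the data shown here, the two numbers lie within the scatter of each other, so compound 2 cannot be set apart from compound 1 on this read-out; only one other number exists beside it.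

The next compound, compound 3 `O=S(=O)(/C=C/c1ccc(O)c(O)c1)CCC1CCCC1`, differs from compound 2 in one place: cyclopentylmethyl in place of cyclopentyl on a saturated chain carbon bound to a sulfonyl sulfur. Among the measured compounds shown here, nothing measured so far shows what that change does. With compound 1 and compound 2 giving numbers within the scatter of each other despite very different groups on the sulfonyl sulfur, no step beyond the scatter is expected from compound 2 to compound 3 in this assay, that is a 1.0-fold lower number from compound 2 to compound 3 (0.02 log units; within the scatter) as the estimated step. For compound 3 in this assay the expected value is 9000 nM, with a range from 4500 nM to 18000 nM.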

Compound 3, half-maximal effective concentration: 6800 nM
Estimate against measurement, compound 3: 1.3-fold (0.12 log units) above; low and high end bracket the measured number.
By their numbers in this assay, from the lowest: compounds 3, 1 and 2 (each within the scatter of the next).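

In this assay, among these compounds, cyclopentylmethyl in place of cyclopentyl on a saturated chain carbon bound to a sulfonyl sulfur gives a 1.4-fold lower number from compound 2 to compound 3 (0.14 log units; within the scatter) and so provides the first step that can be read in one place, and that step lies within the scatter. On this read-out the two groups cannot be told apart at this position, although cyclopentylmethyl carries 6 heavy atoms against 5 for cyclopentyl and both hold the same five-membered non-aromatic ring of carbon only. No outside measurement bears on this result.

From the compounds shown here alone, it remains open whether a cyclopentylethyl group, an amine or a carboxylic acid at this position would give a step beyond the scatter. Also open, going by these compounds, is whether any change to the shared core would do so in this assay as well.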